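The compounds below may be only part of what the source reports. "The series", "measured", "known", "first", "only" and "open" are said of these compounds alone.

Of the compounds shown here, two have been measured so far in a functional assay on RAW264.7 cells (Mus musculus) for inhibition, read by Griess assay, with stated times of 2 h and 12 h; on this read-out higher numbers stand for weaker inhibition and lower numbers for stronger inhibition. Compound 1, `CC/C=C/C=C/CCc1cc(O)c([C@@H]2O[C@H](CO)[C@@H](O)[C@H](O)[C@H]2O)c(O)c1C(=O)OC`, gives 19000 nM. Compound 2, `CCC/C=C/C=C\CCc1cc(O)cc(O)c1`, gives 28000 nM. Among the measured compounds shown here, compound 2 stands at the highest of the two numbers, but its only neighbour is compound 1, and the gap between them is within the scatter, so the two compounds cannot be ordered on these data.

Compound 3, `CCC/C=C/C=C/CCc1cc(O)cc(O)c1`, is the next compound to be measured in this assay. How it differs from compound 2: the two compounds have the same atoms and bonds and differ only in configuration as drawn: 1 of 2 stereo elements differ; a double bond is drawn Z in compound 2 and E in compound 3. For the measured compounds named here, no pair of measured compounds differs in only one place, so no measured step is available to calibrate what this change does; the two measured values in this assay are themselves within the scatter of each other.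

With nothing in the measured series pointing either way, compound 3 is expected to sit within the scatter of compound 2, which gave 28000 nM, and the step from compound 2 to compound 3 is estimated as no change at the digits printed from compound 2 to compound 3 (within the scatter). Compound 3 is therefore estimated at 28000 nM, with a range from 14000 nM to 56000 nM.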

Compound 3, half-maximal inhibitory concentration: 6000 nM
Compound 3: middle estimate off by 4.7-fold (0.67 log units), on the high side, outside the stated range (below it).
By their numbers in this assay, from the lowest: compound 3; then compounds 1 and 2 (each within the scatter of the next).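

The series now has its first single-place step in this assay, and it shows that the read-out responds to double-bond geometry alone: the change gives a 4.7-fold lower number from compound 2 to compound 3 (0.67 log units; beyond the scatter). The step can be assigned to that one double bond, because nothing else separates the pair: the fact that compounds 2 and 3 differ only in the configuration as drawn. The chain therefore counts here through its drawn shape as well as through its atoms, with the E form giving the lower number in this single pair, while compound 1 differs from compound 3 in more than one place and says nothing on this point.

Still open, going by these compounds, is whether the same preference holds at the other double bond of the chain, or on a longer chain, since one pair on one chain cannot show how general the step is. On these data alone, it is also open whether the geometry continues to matter once a carboxylic acid or an amine is carried on the shared core, and whether the step would have the same size there.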